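A few compounds are considered here, and "the series" means these few. Any claim that something is new, unique, unknown or untested is made for them only; others in the source may bear on it.

Measured compounds:
- compound 1 `COc1cc(-c2cc(/C=C/C(=O)c3ccc(Cl)c(Cl)c3)[nH]n2)cc(OC)c1OC`: 53%
- compound 2 `COc1ccc(-c2cc(/C=C/C(=O)c3cc(OC)c(OC)c(OC)c3)[nH]n2)cc1OC`: -87%
- compound 3 `COc1ccc(C(=O)/C=C/c2cc(-c3cc(OC)c(OC)c(OC)c3)n[nH]2)cc1OC`: -94%

In a functional assay on HT-29 cells (Homo sapiens) for cytotoxicity, read by sulforhodamine B assay, with a stated time of 48 h, tested at 10 uM (a lower number here means a stronger effect, a higher number a weaker effect of the compound at the concentration tested), compound 3 stands at the low end of the three numbers; compound 2 lies within the scatter of it, while compound 1 lies well above. Going by the values given here, the single step between measured neighbours, a number 147 percentage points lower from compound 1 to compound 3 (beyond the scatter), concerns the aryl on the carbonyl carbon. Compound 4 `COc1cc(C(=O)/C=C/c2cc(-c3cc(OC)c(OC)c(OC)c3)n[nH]2)cc(OC)c1OC` differs from compound 3 by methoxy in place of hydrogen on an aromatic carbon. Among the compounds with values here, that step touches the aryl on the core, a position no measured step addresses, so no direct guide exists; the values of compound 2 and compound 3, which differ at the other aryl, sit within the scatter. Compound 4 is therefore expected to show a number 6 percentage points higher from compound 3 to compound 4 (within the scatter), nothing beyond the scatter. The estimate for compound 4 is -88%, ranging from -100% to -55%.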

Compound 4, a percentage reported as activity, at one concentration (the size of the read-out at that concentration, not a potency): -86%
For compound 4 the middle estimate is 2 percentage points below the measured one; the range from low to high includes it.
By their numbers in this assay, from the lowest: compounds 3, 2 and 4 (each within the scatter of the next); then compound 1.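

In this assay the step of a number 8 percentage points higher from compound 3 to compound 4 (within the scatter) falls on the aryl on the carbonyl carbon and the step of a number 1 percentage points higher from compound 2 to compound 4 (within the scatter) on the aryl on the core, so methoxy in place of hydrogen leaves the read-out within the scatter on both aryls. The earlier compounds shown here showed only a large step when dimethoxyphenyl replaced dichlorophenyl; these steps show that, with methoxy groups already present, one more changes little at this concentration. Nothing available explains this result.

Going by these compounds, whether an amine or a hydroxyl in place of this methoxy would hold the read-out remains open. So does whether compound 2, compound 3 and compound 4 would separate at lower concentrations.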